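This account rests on a few compounds, and the source may have more. Where it says the series, first, only, none or still open, it means among the compounds named here.

The series shares one fused core, seen in compound 1 `COc1ccc(-n2cnc3cnc(-c4ccc(F)cc4C)cc32)cc1`, which in an ADME assay on S9 fraction from liver (Mus musculus) for metabolic stability, read by LC-MS, using NADPH, with a stated time of 45 min, tested at 3 uM, in the presence of a further agent that is not named here (on this read-out lower numbers stand for lower hepatic extraction and higher numbers for higher hepatic extraction), gives 1. Compound 2 `Cc1cc(F)ccc1-c1cc2c(cn1)ncn2-c1ccc(O)nc1` carries a 6-hydroxypyridin-3-yl group on an aromatic nitrogen of the five-membered ring of that core, and in this assay compound 2 gives "not determined" (no result reported). Compound 2 therefore stands on no number in this read-out, and nothing can be said of how it compares with compound 1.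

Compound 3 `COc1cnc(-n2cnc3cnc(-c4ccc(F)cc4C)cc32)cn1` has not yet been measured. It differs from compound 2 in one place (5-methoxypyrazin-2-yl in place of 6-hydroxypyridin-3-yl on an aromatic nitrogen). Among the compounds with values here, because no step between measured compounds is available, the size of the change from compound 2 to compound 3 in this assay cannot be read from the data, and no direction can be stated from compound 2 itself. What can be drawn on is compound 1, whose hepatic extraction ratio of 1 sits at the top of the scale, and whose substituent, like that of compound 3, carries a methoxy group and no hydrogen-bond donor. On that basis compound 3 is expected to give 0.9 in this assay, with a likely range from 0.7 to 1.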

Compound 3, hepatic extraction ratio: 0.66
For compound 3 the middle estimate is 0.24 above the measured one, and the stated range ends above it.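

In this assay, putting 5-methoxypyrazin-2-yl in place of 4-methoxyphenyl on an aromatic nitrogen of the five-membered ring gives a number 0.34 lower from compound 1 to compound 3 (beyond the scatter), a large step. Compound 1 alone could not show whether the read-out responds to a change at this place, and this step shows that it does, even though both groups carry a methoxy group and differ in the six-membered aromatic ring that bears it. Nothing at hand bears on what lies behind this step.

As far as these compounds go, the step between compound 2 and compound 3 cannot be read, since compound 2 has no number, and the effect of the 6-hydroxypyridin-3-yl group in this read-out stays unknown. The compounds shown also leave open whether the 5-methoxypyrazin-2-yl group would take the hepatic extraction ratio further down or back up if an amine or a longer alkoxy chain such as ethoxy stood in place of its methoxy group.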